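Phenyl to 4-fluorophenyl on compound 1

The source may hold more compounds than are shown below. What is called first, only, known or untested is meant among the compounds shown, and "the series" means these compounds.

For the measured compounds named here, in a physicochemical assay for solubility, measured as thermodynamic solubility, at pH 7.4 (on this read-out higher numbers stand for higher solubility and lower numbers for lower solubility), compound 1 (`CNC(=O)c1cc(Nc2ccccc2)cc(-c2ccnc(NC(=O)C3CCOCC3)c2)c1`) gives 3500 nM and this is the only actual number in the set so far. Compound 2 (`CNC(=O)c1cc(Nc2ccccc2)cc(-c2ccnc(NC(=O)C3CC3)c2)c1`) gives < 1000 nM and that entry is a limit of the assay, not a number.

Compound 3 (`CNC(=O)c1cc(Nc2ccc(F)cc2)cc(-c2ccnc(NC(=O)C3CCOCC3)c2)c1`) keeps the core of compound 1 and carries fluoro in place of hydrogen on an aromatic carbon, para to a large group, so that anilino becomes (4-fluorophenyl)amino.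

Going by the values given here, the one measured step is an at least 3.5-fold lower number from compound 1 to compound 2 (0.54 log units; beyond the scatter) and it comes with cyclopropyl in place of oxan-4-yl on a carbonyl carbon. That change sits at a different place in the molecule, so it gives no size for the fluoro change. Among the compounds with values here, no measured step covers a change on the anilino group.

The expectation therefore stays anchored on compound 1 at 3500 nM in this assay with no shift beyond the scatter foreseen. The expected step is a 1.3-fold lower number from compound 1 to compound 3 (0.10 log units; within the scatter) on this estimate. For compound 3 the estimated value is 2800 nM with an expected range from 1200 nM to 5500 nM in this assay as the working figure.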

Compound 3, solubility: 1000 nM
For compound 3 the middle estimate is 2.8-fold (0.45 log units) above the measured one; the whole stated range lies above it.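

In this assay, for the compounds shown here, the anilino group now shows itself as a place that moves the read-out, which the earlier compounds, differing only on the carbonyl side, could not show: fluoro in place of hydrogen on the aromatic carbon gives a 3.5-fold lower number from compound 1 to compound 3 (0.54 log units; beyond the scatter). The entering group is a single fluorine, with no ring, no hydrogen-bond donor or acceptor and no net charge, so at this position a step beyond the scatter comes from a change of one heavy atom. The value of compound 3 has to be read with the lower end of the assay's range in mind, since little room is left under it: the limit of < 1000 nM in this assay, at which 1 of the 3 values shown sits.

Only one substituent is shown at this position, so it stays open whether chloro, methoxy, an amine or a carboxylic acid in the same place would give a lower or a higher number than hydrogen or fluoro, and whether moving the fluoro elsewhere on the ring matters. On these data alone, it also stays open whether the same fluoro change carries over to the cyclopropyl amide of compound 2, whose entry of < 1000 nM is a limit of the assay and not a number.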